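The source may hold more compounds than are shown below. What is called first, only, known or untested is meant among the compounds shown, and "the series" means these compounds.

Measured so far:
compound 1 `CC(C)S(=O)(=O)N1CCC(CCCC(=O)c2ncco2)CC1` gives 140 nM
compound 2 `Cc1ccc(CN2CCC(CCCC(=O)c3ncco3)CC2)cc1` gives 400 nM

For the measured compounds named here, in an assay on isolated protein for inhibition of Fatty-acid amide hydrolase 1 (Homo sapiens) (a lower number here means a stronger inhibitor, a higher number a weaker inhibitor), compound 2 stands at the highest of the two numbers, and its only neighbour is compound 1, separated by the step of a 2.9-fold higher number from compound 1 to compound 2 (0.46 log units; beyond the scatter). Compound 3 `O=C(CCCC1CCN(Cc2ccccc2Cl)CC1)c1ncco1` differs from compound 2 by 2-chlorophenyl in place of 4-methylphenyl on a saturated chain carbon bound to an amine nitrogen in a ring. Going by the values given here, no measured step varies the group on the saturated chain carbon bound to the amine nitrogen in the ring; the single step in hand, a 2.9-fold higher number from compound 1 to compound 2 (0.46 log units; beyond the scatter), concerns another place and bears only loosely on this change. The expectation is therefore no step beyond the scatter. Compound 3 is estimated at 400 nM, between 130 nM and 1200 nM, the expected step being no change at the digits printed from compound 2 to compound 3 (within the scatter).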

Compound 3, half-maximal inhibitory concentration: 260 nM
For compound 3 the middle estimate is 1.5-fold (0.19 log units) above the measured one, within the range that was stated.
By their numbers in this assay, from the lowest: compounds 1, 3 and 2 (each within the scatter of the next, the first and the last beyond it).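

In this assay, 2-chlorophenyl in place of 4-methylphenyl gives (a 1.5-fold lower number from compound 2 to compound 3 (0.19 log units; within the scatter)), so the two substituted phenyl groups cannot be told apart at this position. The gap from isopropylsulfonyl, beyond the scatter for 4-methylbenzyl, does not hold for 2-chlorobenzyl (a 1.9-fold higher number from compound 1 to compound 3 (0.27 log units; within the scatter)), so it is not shared by both benzyl groups. Nothing available gives a reason for this result.

Still open, as far as these compounds go, is how an unsubstituted benzyl group or 4-chlorobenzyl would compare at this nitrogen. Also open, from the compounds shown here alone, is how an amine or a carboxylic acid on the phenyl ring would compare.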